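This account rests on a few compounds, and the source may have more. Where it says the series, first, only, none or still open, it means among the compounds named here.

Compound 3 `Cc1ccccc1CNc1ncnn1-c1cccc(Cl)c1Cl` gives 200 nM in a functional assay for antagonist activity at P2X purinoceptor 7 (Rattus norvegicus), read by FLIPR and calcium flux (a lower number here means a stronger inhibitor, a higher number a weaker inhibitor), the low end of the three numbers measured: compound 2 `Cc1ccccc1Nc1ncnn1-c1cccc(Cl)c1Cl` gives 240 nM, within the scatter of compound 3, while compound 1 `Clc1cccc(-n2ncnc2Nc2ccccc2)c1Cl` gives 3890 nM, well beyond it. Within the data shown here, the only measured step, a 16-fold lower number from compound 1 to compound 2 (1.21 log units; beyond the scatter), is large and comes from methyl in place of hydrogen on an aromatic carbon. Compound 4 `Clc1cccc(-n2ncnc2NCc2cccnc2)c1Cl` differs from compound 3 by pyridin-3-yl in place of 2-methylphenyl on a saturated chain carbon bound to a nitrogen on an aromatic ring. Among the measured compounds shown here, no measured step covers this change; only the weight that compound 1 and compound 2 attach to the methyl suggests its loss alongside the ring swap may cost something. Compound 4 is therefore expected to give 800 nM in this assay, between 250 nM and 2500 nM, a step of a 4.0-fold higher number from compound 3 to compound 4 (0.60 log units; beyond the scatter) toward a weaker inhibitor.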

Compound 4, half-maximal inhibitory concentration: 1320 nM
For compound 4 the middle estimate is 1.7-fold (0.22 log units) below the measured one; the range from low to high includes it.
By their numbers in this assay, from the lowest: compounds 3 and 2 (each within the scatter of the next); then compound 4; then compound 1.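

In this assay, among these compounds, the first measured change at this position, pyridin-3-yl in place of 2-methylphenyl on the saturated chain carbon, gives a 6.6-fold higher number from compound 3 to compound 4 (0.82 log units; beyond the scatter) and so moves toward a weaker inhibitor. On the nitrogen on the aromatic ring, (pyridin-3-yl)methyl gives a 5.5-fold higher number from compound 2 to compound 4 (0.74 log units; beyond the scatter) in place of 2-methylphenyl but a 2.9-fold lower number from compound 1 to compound 4 (0.47 log units; beyond the scatter) in place of phenyl, so the same group reads in opposite directions depending on what it replaces. No evidence on hand explains the size of these steps.

Open, going by these compounds, is how much of the first step belongs to the ring nitrogen and how much to the methyl, which a plain phenyl on that chain carbon would separate. A pyridin-4-yl or a longer chain would show how far this position tolerates change.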